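Benzyl in Place of Methyl on the Ether Oxygen

A few compounds are considered here, and "the series" means these few. Any claim that something is new, unique, unknown or untested is made for them only; others in the source may bear on it.

Of the compounds shown here, three built on the same core have been tested in a functional assay on K562 cells (Homo sapiens) for cytotoxicity, read by MTT assay, with a stated time of 72 h; a lower number here means a stronger inhibitor, a higher number a weaker inhibitor. Compound 1 `CCCOCNc1n[n+]([O-])c2cc(OC)ccc2[n+]1[O-]` gives 3520 nM. Compound 2 `[O-][n+]1nc(NCOC2CCCCC2)[n+]([O-])c2ccccc21` gives 4880 nM, and compound 3 `COCNc1n[n+]([O-])c2ccccc2[n+]1[O-]` gives 3790 nM. All three numbers lie within the usual scatter of one another, so compound 3 stands alongside the other two rather than apart from them. Within the data shown here, the one comparison between compounds differing in a single place is a 1.3-fold lower number from compound 2 to compound 3 (0.11 log units; within the scatter), where a change of the group on the oxygen on a saturated carbon left the number essentially where it was.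

Compound 4 `[O-][n+]1nc(NCOCc2ccccc2)[n+]([O-])c2ccccc21` has not yet been measured. It differs from compound 3 by phenyl in place of hydrogen on a saturated chain carbon bound to an oxygen on a saturated carbon. This is the same region of the molecule that the earlier comparison probed, and since that comparison stayed within the scatter, no movement beyond the scatter is expected here either. The expected step is a 1.1-fold lower number from compound 3 to compound 4 (0.02 log units; within the scatter). In this assay compound 4 is estimated at 3600 nM, with a likely range from 1500 nM to 8500 nM.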

Compound 4, half-maximal inhibitory concentration: 4690 nM
Estimate against measurement, compound 4: 1.3-fold (0.11 log units) below; low and high end bracket the measured number.
By their numbers in this assay, from the lowest: compounds 1, 3, 4 and 2 (each within the scatter of the next).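

In this assay, phenyl in place of hydrogen on this saturated chain carbon, which turns methyl into benzyl on the ether oxygen, gives a 1.2-fold higher number from compound 3 to compound 4 (0.09 log units; within the scatter) and so shows that this much larger group leaves the number within the scatter. Benzyl in place of cyclohexyl on the same oxygen gives a 1.0-fold lower number from compound 2 to compound 4 (0.02 log units; within the scatter) and adds that an aromatic ring and a saturated ring read alike here. No measurement at hand explains why the number stays so flat across these groups.

As far as these compounds go, all the groups compared on this oxygen are built of carbon and hydrogen only, so it stays open whether an amine or a carboxylic acid there would move the number beyond the scatter. From the compounds shown here alone, it also stays open whether a benzyl carrying a chlorine on its ring would read the same.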